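From 2-methylbenzyl to 2-chlorobenzyl: an expected step

The source may report more compounds than this note shows. Statements on the series, on what has been measured and on what is new or still open speak of the compounds shown alone.

Compound 1 `O=c1ccoc2cc(OCc3cn(Cc4ccccc4)nn3)ccc12`: 42900 nM
Compound 2 `Cc1ccccc1Cn1cc(COc2ccc3c(=O)ccoc3c2)nn1`: > 100000 nM
Compound 3 `O=c1ccoc2cc(OCc3cn(Cc4cccc(F)c4)nn3)ccc12`: > 100000 nM

All three compounds were tested in a functional assay on SW480 cells (Homo sapiens) for cytotoxicity, read by MTT assay, with a stated time of 48 h; a higher number here means a weaker inhibitor, a lower number a stronger inhibitor. Only compound 1 gives a number there. Compound 2 stands at the limit of > 100000 nM in this assay, at which 2 of the 3 values shown sit, which is a limit and not a number. Compound 4 `O=c1ccoc2cc(OCc3cn(Cc4ccccc4Cl)nn3)ccc12` follows from compound 2 by one change, chloro in place of methyl on an aromatic carbon. Among the compounds with values here, no measured step shows this swap directly, but two bear on it. Methyl in place of hydrogen gives an at least 2.3-fold higher number from compound 1 to compound 2 (0.36 log units; beyond the scatter), and fluoro in place of hydrogen gives an at least 2.3-fold higher number from compound 1 to compound 3 (0.36 log units; beyond the scatter). Both lie beyond the scatter and point the same way. The remaining comparison, a step that the two limits leave unreadable from compound 2 to compound 3, adds nothing. Compound 4 keeps a substituent where compound 2 has one, so it is expected to stay close to compound 2 in this assay, with no change beyond the scatter. The expected change is a number no higher from compound 2 to compound 4 (the limit leaves the size open). For compound 4 the estimate is 100000 nM, with an expected range from 45000 nM to 200000 nM.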

Compound 4, half-maximal inhibitory concentration: 23500 nM
The estimate for compound 4 lay 4.3-fold (0.63 log units) above the measured number; the whole stated range lies above it.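

Chloro in place of methyl, at this place ortho to a large group, gives an at least 4.2-fold lower number from compound 2 to compound 4 (0.62 log units; beyond the scatter) in this assay and so brings back a readable number, which shows that the two substituents are not interchangeable here. The same holds against the 3-fluorophenyl group, with an at least 4.2-fold lower number from compound 3 to compound 4 (0.62 log units; beyond the scatter) for this pair. The earlier steps shown here suggested that any substituent on the benzyl ring costs activity, yet compound 4 goes against that, with a 1.8-fold lower number from compound 1 to compound 4 (0.26 log units; within the scatter) and so no separation from the unsubstituted compound 1, while compounds 2 and 3 remain the only cases that fit.

As far as these compounds go, how far compound 4 truly lies from compound 2 stays open, as compound 2 gives only a limit and not a number: the limit of > 100000 nM in this assay, at which 2 of the 4 values shown sit. Also open, from the compounds shown here alone, is whether bromo or methoxy at this place would behave like chloro or like methyl.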